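A few compounds are considered here, and "the series" means these few. Any claim that something is new, unique, unknown or untested is made for them only; others in the source may bear on it.

Measured compounds in a functional assay on PC-3 cells (Homo sapiens) for cytotoxicity, read by MTT assay; a lower number here means a stronger inhibitor, a higher number a weaker inhibitor:
Compound 1, `c1ccc(-c2nnc(-c3c[nH]c4ccccc34)o2)cc1`, gives > 1000000 nM, which is a limit of the assay.
Compound 2, `COc1ccc(-c2nnc(-c3c[nH]c4ccccc34)o2)cc1`, gives > 1000000 nM, likewise a limit.
Compound 3, `COc1cc(-c2nnc(-c3cn(C)c4ccccc34)o2)ccc1OCc1ccccc1`, gives > 1000000 nM, again a limit.

Compound 1 therefore stands only at a limit; no number is known for it, and the same holds for the other two measured compounds: the limit of > 1000000 nM in this assay, at which 3 of the 3 values shown sit. For the measured compounds named here, the one step between measured compounds that differ in a single place, a step that the two limits leave unreadable from compound 1 to compound 2, cannot be sized; both of its ends are limits.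

Compound 4, `Cc1nnc(-c2c[nH]c3ccccc23)o1`, differs from compound 1 by methyl in place of phenyl on an aromatic carbon. Going by the values given here, no measured step bears directly on this change: the step from compound 1 to compound 2 alters a group on the phenyl rather than removing the phenyl, and its size is not readable. With every measured value sitting at the limit, as the limit of > 1000000 nM in this assay, at which 3 of the 3 values shown sit, shows, no step beyond the scatter is expected in this assay ; the expected step from compound 1 to compound 4 is a number no higher from compound 1 to compound 4 (the limit leaves the size open). For compound 4 in this assay the estimate is 1000000 nM, with a range of 300000 nM to 3000000 nM, and it is expected most likely to be reported as a limit once more.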

Compound 4, half-maximal inhibitory concentration: > 1000000 nM
Compound 4 was reported as a limit (the forecaster's own chance of this, stated with the estimate: 85%); the middle value lies on the limit itself.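

No new step can be read between compound 1 and compound 4 in this assay, as both results are limits and not numbers: the limit of > 1000000 nM in this assay, at which 4 of the 4 values shown sit.

The compounds shown leave open whether any change on the shared core, methyl in place of phenyl included, alters cytotoxicity at all.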